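The source may report more compounds than this note shows. Statements on the series, on what has been measured and on what is new or still open speak of the compounds shown alone.

Measured compounds:
compound 1, `CCOC(=O)c1cnn(-c2nc(-c3ccccc3Cl)c(C#N)c(=O)n2C)c1N`, 78 ug/mL in a functional assay, with a stated time of 20 min; a higher number here means a weaker inhibitor, a lower number a stronger inhibitor
compound 2, `Cn1c(NN)nc(-c2ccc(Cl)cc2)c(C#N)c1=O`, 44 ug/mL in this assay

Compound 2 holds the lowest of the two numbers in this assay, and its nearest neighbour is compound 1, whose number lies within the usual scatter of repeated measurements, so the two are not told apart by these data. The step from compound 2 leads to compound 3, `CN(C)c1ccc(-c2nc(NN)n(C)c(=O)c2C#N)cc1`, which has not yet been measured. The change is dimethylamino in place of chloro on an aromatic carbon. Going by the values given here, no pair of measured compounds differs in one place, so there is no measured step to lean on; the expectation rests on the value of compound 2 and on the change itself. In this assay the step from compound 2 to compound 3 is expected to be a 1.1-fold higher number from compound 2 to compound 3 (0.06 log units; within the scatter), which is no change beyond the scatter. Compound 3 is therefore estimated at 50 ug/mL in this assay, within a range from 15 ug/mL to 160 ug/mL.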

Compound 3, half-maximal inhibitory concentration: 81 ug/mL
Estimate against measurement, compound 3: 1.6-fold (0.21 log units) below, within the range that was stated.
By their numbers in this assay, from the lowest: compounds 2, 1 and 3 (each within the scatter of the next).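

Going by these compounds alone, this is the first step read at this position: in this assay, dimethylamino in place of chloro on an aromatic carbon, para to a large group, gives a 1.8-fold higher number from compound 2 to compound 3 (0.27 log units; within the scatter) and so leaves the two compounds untold apart. Thus exchanging the single chlorine atom for a group of three heavy atoms that adds a hydrogen-bond acceptor produces no change beyond the scatter in this assay, a reading that rests on this one pair alone. Nothing at hand bears on why this result arises.

From the compounds shown here alone, whether a primary amine, a methoxy group or a carboxylic acid on this same carbon would give a number beyond the scatter remains open. So does whether a longer chain on the nitrogen of the amine would do so.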